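Bromine for Methyl on the Aryl Ketone: Cytotoxicity Outlook

The compounds below may be only part of what the source reports. "The series", "measured", "known", "first", "only" and "open" are said of these compounds alone.

Three compounds sharing one core, differing only in the aryl group on the carbonyl carbon of the enone, have been tested in an ADME assay on Vero cells (Chlorocebus sabaeus) for cytotoxicity, read by MTT assay, with a stated time of 72 h; on this read-out higher numbers stand for lower toxicity in this test and lower numbers for higher toxicity in this test. Compound 1 `COC(=O)c1cc(-c2cccc(NC(=O)c3ccc(/C=C/C(=O)c4cccc(F)c4)cc3)c2)on1` carries a 3-fluorophenyl there. In this assay compound 1 reaches only a limit of the test, > 40 ug/mL. Compound 2 `COC(=O)c1cc(-c2cccc(NC(=O)c3ccc(/C=C/C(=O)c4ccccc4OC)cc3)c2)on1` carries a 2-methoxyphenyl. In this assay compound 2 likewise gives a limit, > 40 ug/mL. Compound 3 `COC(=O)c1cc(-c2cccc(NC(=O)c3ccc(/C=C/C(=O)c4ccc(C)cc4)cc3)c2)on1` carries a 4-methylphenyl. In this assay compound 3 also stops at a limit, > 80 ug/mL. All three results are limits, so the steps among them cannot be sized: a step that the two limits leave unreadable from compound 1 to compound 2, a step that the two limits leave unreadable from compound 1 to compound 3 and a step that the two limits leave unreadable from compound 2 to compound 3. What they share is summed up by the limit of > 40 ug/mL in this assay, at which 2 of the 3 values shown sit, and the limit of > 80 ug/mL in this assay, at which 1 of the 3 values shown sits: no toxicity appears within the tested span.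

Compound 4 `COC(=O)c1cc(-c2cccc(NC(=O)c3ccc(/C=C/C(=O)c4ccc(Br)cc4)cc3)c2)on1` differs from compound 3 by bromo in place of methyl on an aromatic carbon. Within the data shown here, the steps touching compound 3, a step that the two limits leave unreadable from compound 1 to compound 3 and a step that the two limits leave unreadable from compound 2 to compound 3, are both unreadable and set no direction, and none of the measured compounds showed toxicity in the tested span. Compound 4 is therefore expected to behave the same way. The expected step is a number no higher from compound 3 to compound 4 (the limit leaves the size open), nothing beyond the scatter. The estimate for compound 4 in this assay is 80 ug/mL, with a range from 40 ug/mL to 160 ug/mL.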

Compound 4, half-maximal cytotoxic concentration: > 20 ug/mL
Compound 4 gave a limit, no number (the forecaster's own chance of this, stated with the estimate: 75%); the middle value is on the limit's open side.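

In this assay compound 4 gives > 20 ug/mL, which is a limit and not a number. Its steps to compound 1, compound 2 and compound 3 therefore cannot be read. The compounds shown leave open the concentration, if any, at which each becomes toxic to the cells, and so whether changing the aryl group on the carbonyl carbon alters toxicity at all.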